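From aminoamino to methylsulfanyl on a shared core

The compounds below may be only part of what the source reports. "The series", "measured", "known", "first", "only" and "open" are said of these compounds alone.

compound 1 `Cc1ccc(-c2nc(NN)c3cc(Cl)ccc3n2)cc1` gives 4.17 ug/mL 
compound 2 `Cc1ccc(-c2nc(NOC(=O)c3ccccc3)c3cc(Cl)ccc3n2)cc1` gives 12.1 ug/mL 
compound 3 `Cc1ccc(-c2nc3ccc(Cl)cc3c(=S)n2N)cc1` gives 17 ug/mL 
compound 4 `CSc1nc(-c2ccc(C)cc2)nc2ccc(Cl)cc12` awaits measurement

In a functional assay on HepG2 cells (Homo sapiens) for antiproliferative activity, read by MTT assay, with a stated time of 48 h (a higher number here means a weaker inhibitor, a lower number a stronger inhibitor), compound 1 has the lowest of the three numbers, and compound 3 lies furthest from it, beyond the scatter. The move to compound 4 puts methylsulfanyl in place of aminoamino on an aromatic carbon, next to the ring nitrogen (methylsulfanyl in place of aminoamino on an aromatic carbon). Within the data shown here, no measured compound carries methylsulfanyl, so the evidence is indirect. Among the measured compounds shown here, the only measured step that alters the aminoamino group is benzoyloxy in place of amino on a nitrogen on an aromatic ring, which gave a 2.9-fold higher number from compound 1 to compound 2 (0.46 log units; beyond the scatter) as a modest change. A step of similar size toward a higher number is therefore expected in this assay for compound 4, although this rests on that single step. For compound 4 the estimate amounts to a 2.9-fold higher number from compound 1 to compound 4 (0.46 log units; beyond the scatter) as the expected change. Compound 4 is expected to give 12 ug/mL (estimated range 5 ug/mL to 30 ug/mL).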

Compound 4, half-maximal inhibitory concentration: 13.3 ug/mL
Compound 4: middle estimate off by 1.1-fold (0.04 log units), on the low side; the measured number falls inside the stated range.
By their numbers in this assay, from the lowest: compound 1; then compounds 2, 4 and 3 (each within the scatter of the next).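

Replacing the whole aminoamino group on the aromatic carbon with methylsulfanyl gives a 3.2-fold higher number from compound 1 to compound 4 (0.50 log units; beyond the scatter) in this assay, so this is the first step shown that removes both nitrogens rather than altering the outer one. Both changes shown at this group move the number upward, and compound 4 lies within the scatter of compound 2, so two quite different replacements leave the compounds in the same range, and neither matches compound 1. Nothing available explains this step.

The compounds shown leave open whether it is the loss of the aminoamino group's nitrogens or the arrival of sulfur that counts. A methylamino or methoxy group on the same carbon would help separate the two, and an ethylsulfanyl group would show how a longer chain reads there.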